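The source may report more compounds than this note shows. Statements on the series, on what has been measured and on what is new or still open speak of the compounds shown alone.

Measured so far in an in vitro assay on CHOK cells for displacement of a labelled ligand from growth hormone secretagogue receptor type 1 (Homo sapiens); a higher number here means a weaker inhibitor, a lower number a stronger inhibitor:

- compound 1, `CCc1nc(N)nc(N)c1-c1ccc(NCc2cc(F)c(S(=O)(=O)C(F)(F)F)c(F)c2)cc1`: 21 nM
- compound 2, `CCc1nc(N)nc(N)c1-c1ccc(NCc2ccnc(Cl)c2)cc1`: 110 nM
- compound 3, `Nc1nc(N)c(-c2ccc(NCc3ccnc(Cl)c3)cc2)c(COCc2ccccc2)n1`: 1.5 nM

Compound 3 gives the lowest number of the three in this assay; compound 1 is nearest to it and compound 2 furthest, both gaps beyond the scatter. Within the data shown here, the one single-point step in the set is a 73-fold lower number from compound 2 to compound 3 (1.87 log units; beyond the scatter); it concerns the group on the shared core and leaves the amine-side substituent untouched.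

Compound 4, `CC(C)(C)CNc1ccc(-c2c(N)nc(N)nc2COCc2ccccc2)cc1`, differs from compound 3 only on that amine side: tert-butyl in place of 2-chloropyridin-4-yl on a saturated chain carbon bound to a nitrogen on an aromatic ring. Among the measured compounds shown here, no measured step bears directly on this change. For the measured compounds named here, compounds 1 and 2 differ in the aromatic part attached to the same chain carbon and show clearly different numbers, so the amine-side group does matter, but no measured compound drops the ring altogether. A weakening is expected, so that in this assay compound 4 is estimated at 15 nM, within 3 nM to 80 nM. This expectation corresponds to a step of a 10-fold higher number from compound 3 to compound 4 (1.00 log units; beyond the scatter).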

Compound 4, half-maximal inhibitory concentration: 67 nM
Estimate against measurement, compound 4: 4.5-fold (0.65 log units) below, within the range that was stated.
By their numbers in this assay, from the lowest: compound 3; then compound 1; then compounds 4 and 2 (each within the scatter of the next).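

In this assay the amine side now has a single-point reading (a 45-fold higher number from compound 3 to compound 4 (1.65 log units; beyond the scatter)), with the benzyloxy group on the shared core held constant. At this saturated chain carbon bound to a nitrogen on an aromatic ring, the aromatic 2-chloropyridin-4-yl is therefore clearly preferred to tert-butyl, while the ring-free compound 4 retains a measurable value (67 nM). No evidence is available on why this step has its size.

The change removes the ring, the chlorine and the ring nitrogen together, so phenyl, 2-chlorophenyl or cyclohexyl at this place would be needed to separate their contributions. From the compounds shown here alone, it also remains open whether the same change gives a step of similar size on the core carrying ethyl, as in compound 2.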